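Amide reversal at the pyrazole core: compound 2 to compound 3

The source may hold more compounds than are shown below. What is called first, only, known or untested is meant among the compounds shown, and "the series" means these compounds.

Measured so far:
compound 1 `Cc1cc(C(=O)NCc2ccccc2)nn1Cc1cc(Cl)ccc1OCc1ccccc1` — 39.8 nM
compound 2 `Cc1cc(C(=O)NCc2cccnc2)nn1Cc1cc(Cl)ccc1OCc1ccccc1` — 50.1 nM

Both compounds were run in an assay on CHO-K1 cells for displacement of a labelled ligand from prostaglandin E2 receptor EP1 subtype (Homo sapiens); a lower number here means a stronger inhibitor, a higher number a weaker inhibitor. For the measured compounds named here, compound 2 and compound 1 lie within the scatter of each other; the only measured step, a 1.3-fold higher number from compound 1 to compound 2 (0.10 log units; within the scatter), changes the aryl group on the saturated chain carbon bound to the amide-type nitrogen and is too small to read as a trend.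

Compound 3 `Cc1cc(NC(=O)C2CCCC2)nn1Cc1cc(Cl)ccc1OCc1ccccc1` is not yet measured. The change from compound 2 is (cyclopentylcarbonyl)amino in place of ((pyridin-3-yl)methyl)carbamoyl on an aromatic carbon. Going by the values given here, this reverses the amide and removes the aromatic ring on that side, a change of a different kind from the aryl swap in the one measured step, which therefore gives no direct guide. Among the compounds with values here, with no step bearing on it, the expectation for this assay is a loss of modest size, a 2.4-fold higher number from compound 2 to compound 3 (0.38 log units; beyond the scatter), with wide uncertainty. Compound 3 is estimated at 120 nM, within 25 nM to 600 nM.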

Compound 3, half-maximal inhibitory concentration: 15.9 nM
The estimate for compound 3 lay 7.5-fold (0.88 log units) above the measured number, outside the stated range (below it).
By their numbers in this assay, from the lowest: compound 3; then compounds 1 and 2 (each within the scatter of the next).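

In this assay, this aromatic carbon of the shared core accepts a replacement of the whole group, not only the aryl swap seen earlier: (cyclopentylcarbonyl)amino in place of ((pyridin-3-yl)methyl)carbamoyl gives a 3.2-fold lower number from compound 2 to compound 3 (0.50 log units; beyond the scatter) and in place of benzylcarbamoyl gives a 2.5-fold lower number from compound 1 to compound 3 (0.40 log units; beyond the scatter) as the second step. Among these three compounds, then, the six-membered aromatic ring of the leaving groups is not needed for a low number, and the amide can run in the reversed sense with no loss. Nothing measured accounts for the gain.

From the compounds shown here alone, compound 3 changes amide direction and ring together, so the share of each in the gain stays open. A phenyl or cyclohexyl group on the reversed amide carbonyl would bear on that question, as would a shorter chain such as isopropyl.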